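The source may hold more compounds than are shown below. What is called first, only, known or untested is meant among the compounds shown, and "the series" means these compounds.

Measured in a functional assay on NCI-H460 cells (Homo sapiens) for inhibition, read by MTT assay, with a stated time of 72 h; a lower number here means a stronger inhibitor, a higher number a weaker inhibitor:
- compound 1 `COc1cc(NC(C)CCCNC(=O)Nc2cccc(Cl)c2)c2ncccc2c1`: 37000 nM
- compound 2 `COc1cc(NC(C)CCCNC(=O)NNC(=O)Nc2cccc(F)c2)c2ncccc2c1`: 50000 nM

Only these two compounds have been measured, and compound 2 cannot be told apart from compound 1 on the numbers, since the step between them is a 1.4-fold higher number from compound 1 to compound 2 (0.13 log units; within the scatter). The unmeasured compound 3 `COc1cc(NC(C)CCCNC(=O)NNC(=O)Nc2ccc(O)cc2)c2ncccc2c1` keeps everything in compound 2 except the terminal aryl group, with 4-hydroxyphenyl in place of 3-fluorophenyl on an amide-type nitrogen. Among the compounds with values here, the sole measured step bearing on this is the one from compound 1 to compound 2, a 1.4-fold higher number from compound 1 to compound 2 (0.13 log units; within the scatter), which also altered the substituent on an amide-type nitrogen. Within the data shown here, no measured compound carries the 4-hydroxyphenyl group, so this evidence is indirect. No step beyond the scatter is therefore expected in this assay. The estimated step is a 1.3-fold lower number from compound 2 to compound 3 (0.10 log units; within the scatter). For compound 3 the estimate is 40000 nM, with an expected range of 15000 nM to 100000 nM.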

Compound 3, half-maximal inhibitory concentration: > 100000 nM
Compound 3 was reported as a limit (the forecaster's own chance of this, stated with the estimate: 15%); at least 2.5-fold (0.39 log units) between middle value and limit.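

In this assay compound 3 is reported only as a limit of the assay, not as a number: the limit of > 100000 nM in this assay, at which 1 of the 3 values shown sits. Unlike the earlier step, a 1.4-fold higher number from compound 1 to compound 2 (0.13 log units; within the scatter), the change on this amide-type nitrogen now gives a step beyond the scatter, an at least 2.7-fold higher number from compound 1 to compound 3 (0.43 log units; beyond the scatter), with ((4-hydroxyphenyl)carbamoyl)amino in place of 3-chlorophenyl. The narrower swap of 4-hydroxyphenyl for 3-fluorophenyl gives an at least 2.0-fold higher number from compound 2 to compound 3 (0.30 log units; that floor lies within the scatter), whose floor lies within the scatter, so that pair is not clearly separated on its own.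

From the compounds shown here alone, how far the true value of compound 3 lies past its limit remains open. Going by these compounds, it is also open whether a 4-methoxyphenyl or 4-aminophenyl group on the same nitrogen would behave like 4-hydroxyphenyl or like 3-fluorophenyl.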